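The source may report more compounds than this note shows. Statements on the series, on what has been measured and on what is new or still open speak of the compounds shown alone.

In a functional assay on DU-145 cells (Homo sapiens) for antiproliferative activity, read by MTT assay, with a stated time of 48 h (a lower number here means a stronger inhibitor, a higher number a weaker inhibitor), compound 1 (`C/C(=C\CC/C(C)=C/CC[C@@H]1[C@@]2(C)CCC(=O)C(C)(C)[C@H]2CC[C@@]1(C)O)CC/C=C(\C)C(=O)OCc1cn(-c2ccc(F)cc2)nn1`) gives > 150000 nM, which is a limit and not a number. Compound 2 (`C/C(=C\CC/C(C)=C/CC[C@@H]1[C@@]2(C)CCC(=O)C(C)(C)[C@H]2CC[C@@]1(C)O)CC/C=C(\C)C(=O)OCc1cn(-c2ccccc2C(F)(F)F)nn1`) gives > 150000 nM, also a limit. Compound 3 (`C/C(=C\CC/C(C)=C/CC[C@@H]1[C@@]2(C)CCC(=O)C(C)(C)[C@H]2CC[C@@]1(C)O)CC/C=C(\C)C(=O)OCc1cn(-c2ccccc2Br)nn1`) gives > 150000 nM, again a limit. Compound 3 therefore has no exact value and shares (the limit of > 150000 nM in this assay, at which 3 of the 3 values shown sit).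

Compound 4 (`C#CCOC(=O)/C(C)=C/CC/C(C)=C/CC/C(C)=C/CC[C@@H]1[C@@]2(C)CCC(=O)C(C)(C)[C@H]2CC[C@@]1(C)O`) differs from compound 3 in one place: ethynyl in place of 1-(2-bromophenyl)-1H-1,2,3-triazol-4-yl on a saturated chain carbon bound to an oxygen next to a carbonyl group. Here ethynyl stands in place of 1-(2-bromophenyl)-1H-1,2,3-triazol-4-yl on a saturated chain carbon bound to an oxygen next to a carbonyl group.

The nearest measured evidence is a step that the two limits leave unreadable from compound 1 to compound 3, together with a step that the two limits leave unreadable from compound 2 to compound 3 and a step that the two limits leave unreadable from compound 1 to compound 2. These steps only exchange groups on the aromatic ring, and none removes the whole group that leaves here. They offer no size to carry over, so no firm direction can be expected in this assay. The expected change is a number no higher from compound 3 to compound 4 (the limit leaves the size open), and this is only a rough estimate. The estimated value for compound 4 is 150000 nM, with an expected range from 60000 nM to 300000 nM.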

Compound 4, half-maximal inhibitory concentration: 46100 nM
For compound 4 the middle estimate is 3.3-fold (0.51 log units) above the measured one, and the stated range ends above it.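

In this assay, the steps among compound 1, compound 2 and compound 3 cannot be read, so exchanging groups on the aromatic ring said nothing about this position, and each of those values is only a limit: the limit of > 150000 nM in this assay, at which 3 of the 4 values shown sit.

Putting ethynyl in place of 1-(2-bromophenyl)-1H-1,2,3-triazol-4-yl gives the first readable step, an at least 3.2-fold lower number from compound 3 to compound 4 (0.51 log units; beyond the scatter), and putting it in place of 1-(4-fluorophenyl)-1H-1,2,3-triazol-4-yl gives an at least 3.2-fold lower number from compound 1 to compound 4 (0.51 log units; beyond the scatter). So what sits on this saturated chain carbon does change the read-out, and the change goes toward a lower number when the two rings leave.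

On these data alone, the full size of each step stays open, as each starts from a limit. Also open, as far as these compounds go, is whether the triazole ring, the phenyl ring or both account for the step, and whether a carboxylic acid or a methyl ester at this place would give a similar number.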